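The source may report more compounds than this note shows. Statements on the series, on what has been measured and on what is new or still open speak of the compounds shown alone.

In a physicochemical assay for solubility, measured as kinetic solubility, at pH 2 (a lower number here means a less soluble compound, a higher number a more soluble compound), compound 1 `CC(C)[C@@H](c1ccc(-c2ccc3cccc(F)c3c2)[nH]c1=O)[C@@H]1OC(=O)NC1=O` gives 6900 nM as its measured solubility. Compound 2 `CC(C)C(c1ccc(-c2ccc3cccc(F)c3c2)[nH]c1=O)C1SC(=O)NC1=O` at 11300 nM lies within the scatter of compound 1, while compound 3 `O=C1NC(=O)/C(=C/C2(c3ccc(-c4ccc5cccc(F)c5c4)[nH]c3=O)CC2)O1` at 27400 nM lies beyond the scatter above compound 1. Compound 4 `CC(C)[C@H](C[C@H]1SC(=O)NC1=O)c1ccc(-c2ccc3cccc(F)c3c2)[nH]c1=O` is still unmeasured. Its change from compound 1 (2,4-dioxo-1,3-thiazolidin-5-yl)methyl in place of 2,4-dioxo-1,3-oxazolidin-5-yl on a saturated chain carbon bound to an aromatic carbon and a saturated chain carbon puts (2,4-dioxo-1,3-thiazolidin-5-yl)methyl in place of 2,4-dioxo-1,3-oxazolidin-5-yl on a saturated chain carbon bound to an aromatic carbon and a saturated chain carbon. Going by the values given here, no measured pair isolates this change, yet compound 1 at 6900 nM and compound 2 at 11300 nM sit within the scatter of each other, so no step beyond the scatter is expected in this assay here. The estimated step of a 1.3-fold higher number from compound 1 to compound 4 (0.12 log units; within the scatter) is expected to stay within that scatter. For compound 4 the expected value is 9000 nM within an estimated range of 3500 nM to 22000 nM for repeat measurements.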

Compound 4, solubility: 4900 nM
For compound 4 the middle estimate is 1.8-fold (0.26 log units) above the measured one, within the range that was stated.
By their numbers in this assay, from the lowest: compounds 4, 1 and 2 (each within the scatter of the next, the first and the last beyond it); then compound 3.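

In this assay, going by these compounds alone, the first step that isolates a change at this place, on a saturated chain carbon bound to an aromatic carbon and a saturated chain carbon, gives a 1.4-fold lower number from compound 1 to compound 4 (0.15 log units; within the scatter), which lies within the scatter for (2,4-dioxo-1,3-thiazolidin-5-yl)methyl in place of 2,4-dioxo-1,3-oxazolidin-5-yl. This single step alters both the ring and its link to the chain, and the two groups are not told apart here. Nothing at hand offers an explanation for this result. Still open, on these data alone, is how each of those two alterations would act alone, and whether an amine or a carboxylic acid at this place would give a step beyond the scatter.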